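From a Flexible Amine Chain to a Protected Pyrrolidine

The source may report more compounds than this note shows. Statements on the series, on what has been measured and on what is new or still open speak of the compounds shown alone.

In a functional assay on SU-DHL-6 cells (Homo sapiens) for antiproliferative activity, read by CCK-8 assay, with a stated time of 72 h (a higher number here means a weaker inhibitor, a lower number a stronger inhibitor), compound 1 `COc1ncc(-c2ccc3ncnc(NCCN(C)C)c3c2)cc1NS(C)(=O)=O` gives 1700 nM, the lowest of the two numbers in hand. Its nearest neighbour, compound 2 `COc1ncc(-c2ccc3ncnc(N[C@H]4CCN(C(=O)C(C)(C)C)C4)c3c2)cc1NS(C)(=O)=O`, gives 7600 nM, and the step of a 4.5-fold higher number from compound 1 to compound 2 (0.65 log units; beyond the scatter) marks a clearly weaker inhibitor. Compound 3 `COc1ncc(-c2ccc3ncnc(N[C@H]4CCN(C(=O)OC(C)(C)C)C4)c3c2)cc1NS(C)(=O)=O` carries the change (1-(tert-butoxycarbonyl)pyrrolidin-3-yl in place of 2-(dimethylamino)ethyl on a nitrogen on an aromatic ring). Among the compounds with values here, the only measured step that bears on it is a 4.5-fold higher number from compound 1 to compound 2 (0.65 log units; beyond the scatter), where the same chain gave way to a closely related five-membered ring, so a weakening of similar size is expected, namely a 3.5-fold higher number from compound 1 to compound 3 (0.55 log units; beyond the scatter). Compound 3 is therefore estimated at 6000 nM, within 2500 nM to 15000 nM.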

Compound 3, half-maximal inhibitory concentration: 170 nM
Beside the measured number, compound 3's estimate is 35-fold (1.55 log units) above it; measured number outside the range, below it.
By their numbers in this assay, from the lowest: compound 3; then compound 1; then compound 2.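

The pyrrolidine ring is not a loss at this nitrogen on the aromatic ring: a 10-fold lower number from compound 1 to compound 3 (1.00 log units; beyond the scatter) in this assay shows that it can outperform the 2-(dimethylamino)ethyl chain. What the ring carries decides the outcome, as tert-butoxy in place of tert-butyl on the carbonyl carbon gives a 45-fold lower number from compound 2 to compound 3 (1.65 log units; beyond the scatter) and turns the weakest compound here into the strongest. Nothing available explains why this exchange has so large an effect.

Still open, from the compounds shown here alone, is how a free amine on the ring nitrogen, or a methoxycarbonyl group there, would compare. The mirror-image form of the ring also remains an open question.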